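Moving the carboxy group around: from compound 1 to compound 4

The compounds below may be only part of what the source reports. "The series", "measured", "known", "first", "only" and "open" are said of these compounds alone.

Compound 1 `Cc1c(OCCCCOc2ccc(C(=O)O)cc2Cl)ccc(C(=O)CC2CCCC2)c1O` was tested in an assay on HEK293 cells for positive allosteric modulation of metabotropic glutamate receptor 3 (Rattus norvegicus), read by thallium flux, with a stated time of 2.5 min; a lower number here means that less compound is needed, a higher number that more compound is needed for the effect. In this assay compound 1 gives only a limit of the assay, > 10000 nM, not a number. Compound 3 `CCCC(=O)c1ccc(OCCCCOc2ccc(C(=O)O)cc2C)c(C)c1O` likewise reaches only the limit, > 10000 nM. Compound 2 `Cc1c(OCCCCOc2ccc(C(=O)CC(C)(C)C)c(O)c2C)cccc1C(=O)O`, by contrast, gives a measured value of 300 nM, so the shared core can indeed give a readable number. Two of the three values thus sit at the same place: the limit of > 10000 nM in this assay, at which 2 of the 3 values shown sit.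

Compound 4 `Cc1ccc(C(=O)O)cc1OCCCCOc1ccc(C(=O)CC2CCCC2)c(O)c1C` has not yet been measured. It differs from compound 1 in one place: 5-carboxy-2-methylphenyl in place of 4-carboxy-2-chlorophenyl on an oxygen on a saturated carbon. Among the compounds with values here, no step between two measured compounds matches this change, so its size must be estimated rather than read off. Because compound 2 shows 300 nM, a move toward a measurable value is expected for compound 4. Compound 1 itself gives only a limit of the assay, and compound 4 may still remain there. The step from compound 1 to compound 4 is therefore expected to be an at least 4.0-fold lower number from compound 1 to compound 4 (0.60 log units; beyond the scatter). For compound 4 the estimate is 2500 nM, between 500 nM and 10000 nM.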

Compound 4, half-maximal effective concentration: > 10000 nM
Compound 4: a limit, no number; the forecaster's own chance of this, stated with the estimate: 40%; at least 4.0-fold (0.60 log units) between middle value and limit.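

Within the data shown here, compound 1 and compound 4 each give only a limit of the assay in this assay, not a number, so no step between them can be read. The compounds shown leave open whether 5-carboxy-2-methylphenyl or 4-carboxy-2-chlorophenyl gives the lower number, with most values at one place: the limit of > 10000 nM in this assay, at which 3 of the 4 values shown sit.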